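Sulfinyl-bearing core: phenyl exchanged for dimethylcarbamoyl

A few compounds are considered here, and "the series" means these few. Any claim that something is new, unique, unknown or untested is made for them only; others in the source may bear on it.

Compound 1 `CCC[S+]([O-])c1sc2nc(-c3cccs3)cc(-c3ccccc3)c2c1N` is the reference of the series. Going by the values given here, in an assay for inhibition of 15-hydroxyprostaglandin dehydrogenase [NAD(+)] (Homo sapiens), read by fluorescence, with a stated time of 15 min, in the presence of a further agent that is not named here (on this read-out higher numbers stand for weaker inhibition and lower numbers for stronger inhibition), compound 1 gives 2.1 nM, the only plain number among the three values shown. Compound 2 `CCOC(=O)c1sc2nc(-c3cccs3)cc(-c3ccccc3)c2c1N` reaches only a limit of this assay, > 7500 nM. Compound 3 `CCCCSc1sc2nc(-c3cccs3)cc(-c3ccccc3)c2c1N` likewise reaches only a limit, > 80 nM. Both measured steps leave the core untouched except for the propylsulfinyl group: an at least 3500-fold higher number from compound 1 to compound 2 (3.55 log units; beyond the scatter) and an at least 38-fold higher number from compound 1 to compound 3 (1.58 log units; beyond the scatter), each beyond the scatter and each against compound 1.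

Compound 4 `CCC[S+]([O-])c1sc2nc(-c3cccs3)cc(C(=O)N(C)C)c2c1N` keeps the propylsulfinyl group and changes a different position: dimethylcarbamoyl in place of phenyl on an aromatic carbon. Among the compounds with values here, none of the measured steps touches that position, so no measured step bears on this change; its size can only be guessed from the general run of the series, where every alteration so far has weakened inhibition. A worsening of moderate size is therefore expected, a 14-fold higher number from compound 1 to compound 4 (1.15 log units; beyond the scatter). For compound 4 the estimate in this assay is 30 nM, within 5 nM to 300 nM.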

Compound 4, half-maximal inhibitory concentration: 14.7 nM
Compound 4: the middle estimate sits 2.0-fold (0.31 log units) above what was measured; low and high end bracket the measured number.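

Unlike the earlier steps, which all change the propylsulfinyl group, this one tests the position opposite the ring nitrogen, and in this assay dimethylcarbamoyl in place of phenyl gives a 7.0-fold higher number from compound 1 to compound 4 (0.85 log units; beyond the scatter). The six-membered aromatic ring at this place can therefore be given up with a modest loss: compound 4, with no ring here, still gives 14.7 nM, a plain number and not a limit of the assay. The values shown offer no measured basis for a cause of this step.

With a single replacement at this place, the effects of losing the ring and of gaining the carbonyl stay unseparated; a cyclohexyl group, a pyridyl ring or a simple methyl would separate them. Also open, going by these compounds, is whether a shorter amide, such as the primary carboxamide, or a longer one such as diethylcarbamoyl, would sit closer to compound 1.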